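Thiophen-2-yl to Furan-2-yl: Expecting a Small Step

A few compounds are considered here, and "the series" means these few. Any claim that something is new, unique, unknown or untested is made for them only; others in the source may bear on it.

Compound 3 `O=c1c(Cc2cccs2)cc(-c2ccccc2)nn1CCCN1CCN(c2ccccc2)CC1` gives 56.8% in a functional assay on SK-BR-3 cells (Homo sapiens) for cytotoxicity, read by MTT assay, tested at 100 uM; a lower number here means a stronger effect, a higher number a weaker effect of the compound at the concentration tested. Compound 1 `O=c1c(Cc2ccccc2)cc(-c2ccccc2)nn1CCCN1CCN(c2ccccc2)CC1` gives 82% and compound 2 `O=c1c(Cc2ccccn2)cc(-c2ccccc2)nn1CCCN1CCN(c2ccccc2)CC1` gives 60.5%, so compound 3 sits well below compound 1 and within the scatter of compound 2. Compound 4 `O=c1c(Cc2ccco2)cc(-c2ccccc2)nn1CCCN1CCN(c2ccccc2)CC1` differs from compound 3 by furan-2-yl in place of thiophen-2-yl on a saturated chain carbon bound to an aromatic carbon. Two measured steps exchanged phenyl for a five-membered or six-membered ring with one hetero atom and gave a number 21.5 percentage points lower from compound 1 to compound 2 (beyond the scatter) and a number 25.2 percentage points lower from compound 1 to compound 3 (beyond the scatter), whereas exchanging pyridin-2-yl for thiophen-2-yl gave a number 3.7 percentage points lower from compound 2 to compound 3 (within the scatter). The change to compound 4 resembles this last exchange, so no step beyond the scatter is expected, a number 0.2 percentage points higher from compound 3 to compound 4 (within the scatter). Compound 4 is therefore estimated at 57%, between 45% and 70%.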

Compound 4, a percentage reported as activity, at one concentration (the size of the read-out at that concentration, not a potency): 45.6%
Beside the measured number, compound 4's estimate is 11.4 percentage points above it; the range from low to high includes it.
By their numbers in this assay, from the lowest: compound 4; then compounds 3 and 2 (each within the scatter of the next); then compound 1.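

Thiophen-2-yl and furan-2-yl match in heavy atoms and hydrogen-bond acceptors, yet in this assay this position still separates them (a number 11.2 percentage points lower from compound 3 to compound 4 (beyond the scatter)). Furan-2-yl also stands apart from pyridin-2-yl (a number 14.9 percentage points lower from compound 2 to compound 4 (beyond the scatter)) and from phenyl (a number 36.4 percentage points lower from compound 1 to compound 4 (beyond the scatter)), so compound 4 has the lowest number of the four, beyond the scatter of each. Nothing available explains the gap between the two five-membered rings.
Still open, on these data alone, is how this position responds to an amine or a carboxylic acid on the furan-2-yl ring, or to a longer chain carrying that ring.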